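The source may report more compounds than this note shows. Statements on the series, on what has been measured and on what is new or still open speak of the compounds shown alone.

Measured so far:
- compound 1 `CCCCCCCCNc1nc(SCc2ccc(C(F)(F)F)cc2)nc2ccccc12` — in a functional assay on MGC-803 cells (Homo sapiens) for cytotoxicity, read by MTT assay, with a stated time of 72 h (a higher number here means a weaker inhibitor, a lower number a stronger inhibitor), compound 1 gives 12600 nM
- compound 2 `FC(F)(F)c1ccc(CSc2nc(N3CCCCC3)c3ccccc3n2)cc1` — compound 2 gives 18600 nM
- compound 3 `CCOc1ccccc1Nc1nc(SCc2ccc(C(F)(F)F)cc2)nc2ccccc12` — compound 3 reaches only the assay limit, > 50000 nM

Compound 1 holds the lowest of the two numbers; the nearest is compound 2, with a 1.5-fold higher number from compound 1 to compound 2 (0.17 log units; within the scatter). Compound 4 `O=[N+]([O-])c1cccc(Nc2nc(SCc3ccc(C(F)(F)F)cc3)nc3ccccc23)c1` has not yet been measured. It differs from compound 1 by 3-nitrophenyl in place of octyl on a nitrogen on an aromatic ring. Among the compounds with values here, one measured step bears on this: an at least 3.9-fold higher number from compound 1 to compound 3 (0.59 log units; beyond the scatter), where an aromatic ring also replaced octyl on the same nitrogen; an at least 2.6-fold higher number from compound 2 to compound 3 (0.42 log units; beyond the scatter) points the same way. A weakening step beyond the scatter is therefore expected, a 3.2-fold higher number from compound 1 to compound 4 (0.50 log units; beyond the scatter). Compound 4 is estimated at 40000 nM, between 15000 nM and 100000 nM.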

Compound 4, half-maximal inhibitory concentration: > 50000 nM
Compound 4 ended at the assay's limit; the forecaster's own chance of this, stated with the estimate: 40%; middle value at least 1.2-fold (0.09 log units) away from the limit.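

In this assay, the loss seen with 2-ethoxyphenyl returns with a differently substituted ring, 3-nitrophenyl, as an at least 3.9-fold higher number from compound 1 to compound 4 (0.59 log units; beyond the scatter) shows, so it is not tied to that single aromatic group. Compound 4 also sits apart from the piperidine compound, with an at least 2.6-fold higher number from compound 2 to compound 4 (0.42 log units; beyond the scatter). The step from compound 3 to compound 4 cannot be read, because both compounds stop at the same limit: the limit of > 50000 nM in this assay, at which 2 of the 4 values shown sit.

From the compounds shown here alone, how far past that limit either compound lies remains open. So does whether an unsubstituted phenyl, a benzyl group or a butyl chain on this nitrogen would stay close to compound 1.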